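Diazoketone to chloromethyl ketone on a second lipid chain

The source may report more compounds than this note shows. Statements on the series, on what has been measured and on what is new or still open speak of the compounds shown alone.

In a functional assay on MOLT-3 cells (Homo sapiens) (a lower number here means a stronger inhibitor, a higher number a weaker inhibitor), compound 1, whose structure is `CC(=O)N[C@@H](CSC/C=C(\C)CC/C=C(\C)CCC=C(C)C)C(=O)C=[N+]=[N-]`, gives 32200 nM. Compound 2, with structure `CCCCCCCCCCCCSC[C@H](NC(C)=O)C(=O)C=[N+]=[N-]`, gives 22900 nM in this assay, a value within the usual scatter of that of compound 1. The difference between the cores of compound 1 and compound 2 is not broken down here. Compound 3, `CC(=O)N[C@@H](CSC/C=C(\C)CC/C=C(\C)CCC=C(C)C)C(=O)CCl`, is obtained from compound 1 by the change (a group of 2 heavy atoms (1 carbon, 1 chlorine; no ring) in place of a group of 3 heavy atoms (1 carbon, 2 nitrogen; no ring), on a carbonyl carbon), and this step is a 23-fold lower number from compound 1 to compound 3 (1.36 log units; beyond the scatter). In this assay compound 3 gives 1400 nM.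

Compound 4, with structure `CCCCCCCCCCCCSC[C@H](NC(C)=O)C(=O)CCl`, has not yet been measured in this assay. Within the data shown here, it is obtained from compound 2 by the change (a group of 2 heavy atoms (1 carbon, 1 chlorine; no ring) in place of a group of 3 heavy atoms (1 carbon, 2 nitrogen; no ring), on a carbonyl carbon), which is the same change as the one that leads from compound 1 to compound 3, made at the same place on the other core. Since the two measured cores lie close to each other in this assay, the step from compound 2 to compound 4 is expected to be of a size similar to the earlier one, about a 21-fold lower number from compound 2 to compound 4 (1.32 log units; beyond the scatter). Compound 4 is accordingly estimated to give 1100 nM in this assay, with a likely range from 400 nM to 3500 nM.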

Compound 4, half-maximal inhibitory concentration: 2300 nM
Compound 4: the middle estimate sits 2.1-fold (0.32 log units) below what was measured; the range from low to high includes it.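

In this assay, putting chloromethyl on the carbonyl carbon in place of the diazo-bearing group also lowers the number on the second lipid chain, a 10-fold lower number from compound 2 to compound 4 (1.00 log units; beyond the scatter). Set beside the step on the core of compound 1, the change carries over in direction, and the two sizes cannot be told apart: the same change on two cores in this assay, a 23-fold lower number (1.36 log units; beyond the scatter) from compound 1 to compound 3 and a 10-fold lower number (1.00 log units; beyond the scatter) from compound 2 to compound 4, 2.3-fold (0.36 log units) apart, within the scatter of two such steps. Among these compounds, this agreement rests on only two cores, each bearing a lipid chain, so it does not show that the change would carry over to a core of another kind, nor does it say how the change acts in these cells.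

The compounds shown leave open whether another group on the carbonyl carbon, such as bromomethyl or fluoromethyl, would give numbers like those of compound 3 and compound 4. They also leave open how a shorter chain, a chain ending in a carboxylic acid, or a free amine in place of the acetyl amide would fare in this assay.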